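Cyclopropylcarbonyl to ethynylcarbonyl on the shared amide

The source may report more compounds than this note shows. Statements on the series, on what has been measured and on what is new or still open speak of the compounds shown alone.

Three compounds of this series have numbers in a functional assay on KYSE-450 cells (Homo sapiens) for inhibition, read by MTT assay, with a stated time of 48 h; on this read-out lower numbers stand for stronger inhibition and higher numbers for weaker inhibition. Compound 2 `COc1ccc(CN(C(=O)C2CC2)c2cc(OC)c(OC)c(OC)c2)cc1O` gives 80 nM, the lowest of the three and beyond the scatter from both others. Compound 3 `C/C=C/C(=O)N(Cc1cc(OC)c(OC)c(OC)c1)c1ccc(OC)c(O)c1` gives 9160 nM, and compound 1 `C/C=C/C(=O)N(Cc1cccc(O)c1)c1cc(OC)c(OC)c(OC)c1` gives 14700 nM. Going by the values given here, compounds 1 and 3 differ from compound 2 in more than one place, so no single step between them and compound 2 is counted; their numbers only show that the two with a but-2-enoyl amide sit far above compound 2.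

Compound 4 `C#CC(=O)N(Cc1ccc(OC)c(O)c1)c1cc(OC)c(OC)c(OC)c1` keeps the whole of compound 2 apart from the acyl group: ethynyl in place of cyclopropyl on a carbonyl carbon. Among the compounds with values here, no measured pair shows this change alone. The step from compound 2 to compound 4 is expected to be upward, beyond the scatter, a 19-fold higher number from compound 2 to compound 4 (1.27 log units; beyond the scatter), given that the only other acyl variants in this assay, compound 1 at 14700 nM and compound 3 at 9160 nM, lie far above compound 2. Compound 4 is estimated at 1500 nM in this assay, within a range of 150 nM to 15000 nM.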

Compound 4, half-maximal inhibitory concentration: 570 nM
Beside the measured number, compound 4's estimate is 2.6-fold (0.42 log units) above it, and the stated range covers the measured number.
By their numbers in this assay, from the lowest: compound 2; then compound 4; then compounds 3 and 1 (each within the scatter of the next).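

In this assay, the acyl position now has a reading for a single change: ethynyl in place of cyclopropyl on a carbonyl carbon gives a 7.1-fold higher number from compound 2 to compound 4 (0.85 log units; beyond the scatter). The position is therefore sensitive to this change, yet with no ring on the carbonyl carbon compound 4 still gives 570 nM, so a number of this order does not depend on the three-membered ring. Nothing at hand offers a reason for the size of the step.

With one pair, the loss of the ring cannot be separated from the entry of the triple bond. Going by these compounds, how an isopropyl or cyclobutyl group, or an acyl chain carrying an amine, would read on the same core remains open.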